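Replacing the dioxolane side chain of compound 3

The source may report more compounds than this note shows. Statements on the series, on what has been measured and on what is new or still open speak of the compounds shown alone.

In a functional assay on A-375 cells (Homo sapiens) for cytotoxicity, read by MTT assay, with a stated time of 72 h (a lower number here means a stronger inhibitor, a higher number a weaker inhibitor), three compounds sharing one core have been measured. Compound 1 (`O=C1c2c[n+]([O-])c3ccccc3c2C(=O)c2c1c1ccccc1n2Cc1cn([C@@H]2C[C@H](O)[C@@H](CO)O2)nn1`) gives 20 nM, compound 2 (`CC1(C)OCC(Cn2cc(Cn3c4c(c5ccccc53)C(=O)c3c[n+]([O-])c5ccccc5c3C4=O)nn2)O1`) gives 330 nM, and compound 3 (`CC1(C)O[C@@H](CO)[C@H](Cn2cc(Cn3c4c(c5ccccc53)C(=O)c3c[n+]([O-])c5ccccc5c3C4=O)nn2)O1`) gives 190 nM. Compound 3 therefore stands level with compound 2 within the scatter, and both lie well above compound 1.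

Compound 4 (`O=C1c2c[n+]([O-])c3ccccc3c2C(=O)c2c1c1ccccc1n2Cc1cn([C@H]2C[C@H](O)[C@@H](CO)O2)nn1`) departs from compound 3 in one place: 4-hydroxy-5-(hydroxymethyl)oxolan-2-yl in place of (5-(hydroxymethyl)-2,2-dimethyl-1,3-dioxolan-4-yl)methyl on an aromatic nitrogen. The entering 4-hydroxy-5-(hydroxymethyl)oxolan-2-yl group is also found in compound 1, but one of its defined stereocentres is drawn the other way in compound 4.

The most relevant measurement is a 9.5-fold higher number from compound 1 to compound 3 (0.98 log units; beyond the scatter), a modest step that runs opposite to the change considered here. The large 17-fold higher number from compound 1 to compound 2 (1.22 log units; beyond the scatter) points the same way, whereas a 1.7-fold lower number from compound 2 to compound 3 (0.24 log units; within the scatter) stays within the scatter. These steps favour a lower number for compound 4 in this assay. However, no measured pair shows what the altered stereocentre does, so only part of the gap to compound 1 is expected to be recovered.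

The expected step is a 4.2-fold lower number from compound 3 to compound 4 (0.63 log units; beyond the scatter). For compound 4 the estimated value is 45 nM, with an expected range of 15 nM to 150 nM.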

Compound 4, half-maximal inhibitory concentration: 390 nM
The estimate for compound 4 lay 8.7-fold (0.94 log units) below the measured number; the whole stated range lies below it.
By their numbers in this assay, from the lowest: compound 1; then compounds 3, 2 and 4 (each within the scatter of the next, the first and the last beyond it).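

In this assay, the 4-hydroxy-5-(hydroxymethyl)oxolan-2-yl group on the aromatic nitrogen does not bring the low number of compound 1 with it: the configuration of the group decides the outcome, with a 20-fold higher number from compound 1 to compound 4 (1.29 log units; beyond the scatter). Exchanging the dioxolane side chain for this group as drawn in compound 4 brings no gain, since a 2.1-fold higher number from compound 3 to compound 4 (0.31 log units; beyond the scatter) is a modest step the wrong way, and a 1.2-fold higher number from compound 2 to compound 4 (0.07 log units; within the scatter) leaves compound 4 level with compound 2 within the scatter. The large gap can be assigned to the single stereocentre at a saturated ring carbon, drawn S in compound 1 and R in compound 4, because the comparison rests on one fact: the fact that compounds 1 and 4 differ only in the configuration as drawn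

The compounds shown leave open whether the other two stereocentres of the oxolane ring are as sensitive as this one. They also leave open whether an amine or a methoxy group in place of the ring hydroxy group would keep the low number of compound 1, or whether the hydroxymethyl group could be replaced by a longer chain.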